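This account rests on a few compounds, and the source may have more. Where it says the series, first, only, none or still open, it means among the compounds named here.

Compound 1 `CC(C)=CC(=O)OCc1cc(=O)oc2ccc(Cl)cc12`: > 10 ug/mL (a limit)
Compound 2 `COc1ccc2c(COC(=O)C=C(C)C)cc(=O)oc2c1`: > 10 ug/mL (a limit)

In a functional assay on HCT-116 cells (Homo sapiens) for inhibition (a higher number here means a weaker inhibitor, a lower number a stronger inhibitor), compound 1 gives > 10 ug/mL, which is a limit of the assay and not a number. Compound 2 offers no firmer footing, as both measured compounds stop there: the limit of > 10 ug/mL in this assay, at which 2 of the 2 values shown sit. Compound 3 `COc1ccc2oc(=O)cc(COC(=O)C=C(C)C)c2c1` keeps the core of compound 1 but has methoxy in place of chloro on an aromatic carbon. Among the compounds with values here, no measured step shows the size of this change, so the expected step, a step that the limit leaves unreadable from compound 1 to compound 3, stays within the usual scatter. For compound 3 the estimate is 15 ug/mL, with an expected range of 7 ug/mL to 30 ug/mL.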

Compound 3, half-maximal inhibitory concentration: > 10 ug/mL
Compound 3 gave a limit, no number (the forecaster's own chance of this, stated with the estimate: 85%); the middle value is on the limit's open side.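

No step from compound 1 to compound 3 can be read, since both results are limits and not numbers: the limit of > 10 ug/mL in this assay, at which 3 of the 3 values shown sit.

The compounds shown leave open whether swapping chloro for methoxy changes inhibition at all in this assay.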